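The source may report more compounds than this note shows. Statements on the series, on what has been measured and on what is new or still open speak of the compounds shown alone.

In a functional assay on the whole organism with Rattus norvegicus as the target (a lower number here means that less compound is needed, a higher number that more compound is needed for the effect), compound 1 (`COc1cc(C)nc(OC)c1NC(=O)N(Cc1ccc(Oc2ccc(F)cc2)cc1)C1CCCCCC1`) gives 0.032 mg/kg. Compound 2 (`COc1nc(C)cc(SC)c1NC(=O)N(Cc1ccc(Oc2ccc(F)cc2)cc1)C1CCCCCC1`) is reported only as a limit, < 0.032 mg/kg. From the compounds shown here alone, compound 3 (`CSc1nc(C)cc(Cl)c1NC(=O)N(Cc1ccc(Oc2ccc(F)cc2)cc1)C1CCCCCC1`) is also reported only as a limit, < 0.1 mg/kg, so its exact standing remains open. Compound 4 (`Cc1cc(C)c(NC(=O)N(Cc2ccc(Oc3ccc(F)cc3)cc2)C2CCCCCC2)c(C)n1`) differs from it by a group of 9 heavy atoms (8 carbon, 1 nitrogen; one six-membered aromatic ring with 1 hetero atom) in place of a group of 10 heavy atoms (7 carbon, 1 nitrogen, 1 sulfur, 1 chlorine; one six-membered aromatic ring with 1 hetero atom), on an amide-type nitrogen, with 2,4,6-trimethylpyridin-3-yl entering on the amide-type nitrogen. Among the compounds with values here, three measured steps bear on this change: a number no higher from compound 1 to compound 2 (the limit leaves the size open), a step that the limit leaves unreadable from compound 1 to compound 3 and a step that the two limits leave unreadable from compound 2 to compound 3. None has a readable size, so no firm direction is expected in this assay. The expectation rests mainly on compound 1 at 0.032 mg/kg. The expected step is a step that the limit leaves unreadable from compound 3 to compound 4. The estimate for compound 4 is 0.05 mg/kg, with an expected range from 0.015 mg/kg to 0.2 mg/kg.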

Compound 4, dose for half-maximal effect: 0.044 mg/kg
The estimate for compound 4 lay 1.1-fold (0.06 log units) above the measured number; measured number inside the range.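

In this assay, placing 2,4,6-trimethylpyridin-3-yl on the amide-type nitrogen gives a 1.4-fold higher number from compound 1 to compound 4 (0.14 log units; within the scatter), so an exact number shows that a group of only carbon and nitrogen atoms can stand here without a change beyond the scatter. The other readable comparison is an at least 1.3-fold higher number from compound 2 to compound 4 (0.13 log units; that floor lies within the scatter), which sets only a floor. The remaining step cannot be read, as compound 3 is reported only as a limit: the limit of < 0.1 mg/kg in this assay, at which 1 of the 4 values shown sits.

From the compounds shown here alone, how far compound 2 and compound 3 lie from their limits stays open. So does the outcome in this assay for an amine or a carboxylic acid on this ring, or for a longer chain in place of a methyl group.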